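The source may report more compounds than this note shows. Statements on the series, on what has been measured and on what is new or still open speak of the compounds shown alone.

Compound 1 `COc1cc(-n2cnc3ccc(-c4ccccc4)cc32)cc(OC)c1OC`: 2290 nM
Compound 2 `COc1cc(-n2cnc3ccc(-c4ccc(C(F)(F)F)cc4)cc32)cc(OC)c1OC`: 760 nM

Going by the values given here, in a functional assay on MCF7 cells (Homo sapiens) for antiproliferative activity, read by MTT assay, with a stated time of 72 h (on this read-out higher numbers stand for weaker inhibition and lower numbers for stronger inhibition), compound 2 gives 760 nM, the lower of the two numbers measured so far. Compound 3 `COc1cc(-n2cnc3ccc(-c4cccc(F)c4)cc32)cc(OC)c1OC` has not yet been measured. It differs from compound 2 by 3-fluorophenyl in place of 4-(trifluoromethyl)phenyl on an aromatic carbon. Among the compounds with values here, one measured step bears on this change: a 3.0-fold lower number from compound 1 to compound 2 (0.48 log units; beyond the scatter), with trifluoromethyl in place of hydrogen on an aromatic carbon. Compound 3 has no trifluoromethyl, so its number is expected to move back towards that of compound 1, at 2290 nM. Within the data shown here, no measured compound carries 3-fluorophenyl, so the size of the move remains uncertain. The expected change is a 2.1-fold higher number from compound 2 to compound 3 (0.32 log units; beyond the scatter), towards a higher number. In this assay the estimate for compound 3 is 1600 nM, with an expected range of 700 nM to 3500 nM.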

Compound 3, half-maximal inhibitory concentration: 2350 nM
Compound 3: the middle estimate sits 1.5-fold (0.17 log units) below what was measured, and the stated range covers the measured number.
By their numbers in this assay, from the lowest: compound 2; then compounds 1 and 3 (each within the scatter of the next).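

In this assay, the change gives a 3.1-fold higher number from compound 2 to compound 3 (0.49 log units; beyond the scatter), so 3-fluorophenyl does not keep the lower number that 4-(trifluoromethyl)phenyl gives on the shared core. Compared with the unsubstituted phenyl of compound 1, fluoro in place of hydrogen gives a 1.0-fold higher number from compound 1 to compound 3 (0.01 log units; within the scatter), which leaves compound 1 and compound 3 indistinguishable in this assay and compound 2 as the only one of the three set apart. Nothing available explains why these two substituents differ here.

From the compounds shown here alone, the two substituted rings differ in both the group and its place, so it stays open whether the lower number of compound 2 belongs to the trifluoromethyl itself or to where it sits. Going by these compounds, how an amine, a carboxylic acid or a nitrile on this ring would compare also remains open.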